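The source may report more compounds than this note shows. Statements on the series, on what has been measured and on what is new or still open speak of the compounds shown alone.

In a functional assay on BJAB cells (Homo sapiens) for antiproliferative activity, with a stated time of 4 days (a higher number here means that more compound is needed for the effect, a lower number that less compound is needed), the three measured compounds gave:

compound 1 `Cc1nn(-c2nc(-c3ccc(Cl)c(Cl)c3)c(SC(C)C)s2)c(C(=O)O)c1-c1cnn(C)c1`: 6800 nM
compound 2 `Cc1nn(-c2nc(-c3ccc(Cl)c(Cl)c3)c(SC(C)C)s2)c(C(=O)O)c1-c1cccc(C(F)(F)F)c1`: 22000 nM
compound 3 `Cc1nn(-c2nc(-c3ccc(Cl)c(Cl)c3)c(SC(C)C)s2)c(C(=O)O)c1-c1cccc(Cl)c1C`: 5100 nM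

Compound 3 has the lowest number, yet its gap to compound 1, a 1.3-fold lower number from compound 1 to compound 3 (0.12 log units; within the scatter), lies within the scatter; only compound 2 stands clearly apart, as a 4.3-fold lower number from compound 2 to compound 3 (0.63 log units; beyond the scatter) shows. Compound 4 `Cc1nn(-c2nc(-c3ccc(Cl)c(Cl)c3)c(SC(C)C)s2)c(C(=O)O)c1-c1cnccn1` differs from compound 3 by pyrazin-2-yl in place of 3-chloro-2-methylphenyl on an aromatic carbon. The measured steps at this same carbon are a 3.2-fold higher number from compound 1 to compound 2 (0.51 log units; beyond the scatter) and a 1.3-fold lower number from compound 1 to compound 3 (0.12 log units; within the scatter), so the 1-methyl-1H-pyrazol-4-yl of compound 1 and the 3-chloro-2-methylphenyl of compound 3 give similar numbers, while 3-(trifluoromethyl)phenyl gives a higher one. Pyrazin-2-yl being another small heteroaromatic ring, the expected step is a 1.8-fold higher number from compound 3 to compound 4 (0.25 log units; within the scatter), a slight rise within or near the scatter. Compound 4 is thus expected to give 9000 nM, between 3500 nM and 25000 nM.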

Compound 4, half-maximal effective concentration: 14000 nM
Compound 4: the middle estimate sits 1.6-fold (0.19 log units) below what was measured; the range from low to high includes it.
By their numbers in this assay, from the lowest: compounds 3 and 1 (each within the scatter of the next); then compounds 4 and 2 (each within the scatter of the next).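

In this assay, the two nitrogen-containing rings at this carbon do not give similar numbers: a 2.1-fold higher number from compound 1 to compound 4 (0.31 log units; beyond the scatter), and a 2.7-fold higher number from compound 3 to compound 4 (0.44 log units; beyond the scatter), so a small heteroaromatic ring does not by itself keep the number low. Instead, pyrazin-2-yl falls close to 3-(trifluoromethyl)phenyl, with a 1.6-fold lower number from compound 2 to compound 4 (0.20 log units; within the scatter). No measurement available here explains why these rings differ.

On these data alone, how a pyridin-2-yl ring or an open-chain amine at this carbon would compare remains open. So does whether any group there could bring the number far below those of compound 3 and compound 1.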